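The source may hold more compounds than are shown below. What is called first, only, known or untested is meant among the compounds shown, and "the series" means these compounds.

Measured so far:
compound 1, `CC1=NC(C)=C([N+](=O)[O-])C(c2cccnc2)/C1=C(\O)OC(C)C`, gives 28500 nM in a functional assay (cardiac atrium) for agonist activity, with Cavia porcellus as the target; a higher number here means that more compound is needed for the effect, a lower number that less compound is needed.
compound 2, `CC1=NC(C)=C([N+](=O)[O-])C(c2ccncc2)/C1=C(\O)OC(C)C`, gives 8050 nM in this assay.

Of these two numbers compound 1 stands highest; its nearest neighbour is compound 2, reached by a 3.5-fold lower number from compound 1 to compound 2 (0.55 log units; beyond the scatter), a modest step. Compound 3, `COCCO/C(O)=C1\C(C)=NC(C)=C([N+](=O)[O-])C1c1cccnc1`, has not yet been measured in this assay. It differs from compound 1 in one place: 2-methoxyethyl in place of isopropyl on an oxygen on an unsaturated carbon. Among the measured compounds shown here, no measured step bears on this change; the single step known, a 3.5-fold lower number from compound 1 to compound 2 (0.55 log units; beyond the scatter), alters the group on the saturated ring carbon and leaves the oxygen on the unsaturated carbon untouched, so it says nothing about what the new chain does. With nothing to draw on, the expected outcome for compound 3 is no step beyond the scatter, that is an expected step of no change at the digits printed from compound 1 to compound 3 (within the scatter), with a wide range around it. Compound 3 is therefore estimated at 28500 nM, expected to fall between 7000 nM and 110000 nM.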

Compound 3, half-maximal effective concentration: 49400 nM
The estimate for compound 3 lay 1.7-fold (0.24 log units) below the measured number; low and high end bracket the measured number.
By their numbers in this assay, from the lowest: compound 2; then compounds 1 and 3 (each within the scatter of the next).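

Exchanging isopropyl for 2-methoxyethyl on the oxygen on the unsaturated carbon gives a 1.7-fold higher number from compound 1 to compound 3 (0.24 log units; within the scatter) in this assay, so this change cannot be told apart from repeated measurement. Among the compounds shown here, this is the first view of that position: while the earlier step altered only the pyridinyl group on the saturated ring carbon, this one holds pyridin-3-yl fixed and shows that these two chains, one of them carrying an ether oxygen, give numbers within the scatter of each other. Nothing measured on these compounds accounts for this outcome.

As far as these compounds go, it remains open whether a longer chain, or one ending in an amine or a carboxylic acid, would move the number beyond the scatter at this place. Also open, from the compounds shown here alone, is whether 2-methoxyethyl behaves the same way alongside the pyridin-4-yl group of compound 2.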